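A few compounds are considered here, and "the series" means these few. Any claim that something is new, unique, unknown or untested is made for them only; others in the source may bear on it.

In an ADME assay on microsomes from liver (Homo sapiens) for metabolic stability (a lower number here means slower removal, a higher number faster removal of the compound), compound 1 `Cc1ccc([C@H](C)NC(=O)Cn2nnc3ccccc3c2=O)cc1` gives < 9.9 mL/min/kg and that reading is a limit of the assay, not a number. Compound 2 `COc1ccc([C@H](C)NC(=O)Cn2nnc3ccccc3c2=O)cc1` gives 13 mL/min/kg and compound 3 `C[C@H](NC(=O)Cn1nnc2ccccc2c1=O)c1ccc(F)cc1` gives 31 mL/min/kg as measured numbers. Within the data shown here, compound 4 `COc1ccc2nnn(CC(=O)N[C@@H](C)c3ccc(C)cc3)c(=O)c2c1` carries one change on the core of compound 1, methoxy in place of hydrogen on an aromatic carbon, and no measured step makes that exact change. The closest guide is the methoxy step an at least 1.3-fold higher number from compound 1 to compound 2 (0.11 log units; that floor lies within the scatter) at a different place in the molecule, where methoxy replaces methyl. The fluoro steps an at least 3.1-fold higher number from compound 1 to compound 3 (0.49 log units; beyond the scatter) and a 2.4-fold higher number from compound 2 to compound 3 (0.38 log units; beyond the scatter) involve a group that compound 4 lacks, so they count for less. A small rise is therefore expected in this assay as an at least 1.3-fold higher number from compound 1 to compound 4 (0.11 log units; that floor lies within the scatter) and it may stay within the scatter. Compound 4 is estimated at 13 mL/min/kg with an expected range of 8 mL/min/kg to 26 mL/min/kg for its clearance.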

Compound 4, clearance: 58 mL/min/kg
The estimate for compound 4 lay 4.5-fold (0.65 log units) below the measured number, outside the stated range (above it).
By their numbers in this assay, from the lowest: compound 2; then compounds 3 and 4 (each within the scatter of the next). At a limit, below all of these: compound 1.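

On an aromatic carbon of the fused system of two rings, methoxy in place of hydrogen gives in this assay an at least 5.8-fold higher number from compound 1 to compound 4 (0.76 log units; beyond the scatter). Among these compounds, the earlier methoxy change, at a different place in the molecule and replacing methyl, showed no rise beyond the scatter, so this is the first methoxy change with a clear rise. Compound 1 stands at a limit and not a number, so this step is only a floor: the limit of < 9.9 mL/min/kg in this assay, at which 1 of the 4 values shown sits.

As far as these compounds go, whether the rise belongs to methoxy itself or to any group on this carbon stays open. A hydroxyl, an amine or a fluoro at this position would help separate the two.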